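Fluorine for Chlorine on the Aryl Ketone of Compound 1

The compounds below may be only part of what the source reports. "The series", "measured", "known", "first", "only" and "open" are said of these compounds alone.

Measured so far:
compound 1, `COc1cc(-c2cc(/C=C/C(=O)c3ccc(Cl)c(Cl)c3)[nH]n2)cc(OC)c1OC`, gives 102%
compound 2, `COc1ccc(-c2cc(/C=C/C(=O)c3cc(OC)c(OC)c(OC)c3)[nH]n2)cc1OC`, gives 95%
compound 3, `COc1ccc(-c2cc(/C=C/C(=O)c3ccc(N)cc3)[nH]n2)cc1`, gives 98%

All three were tested in a functional assay on MOLT-4 cells (Homo sapiens) for cytotoxicity, read by sulforhodamine B assay, with a stated time of 48 h, tested at 0.1 uM; a higher number here means a weaker effect of the compound at the concentration tested, a lower number a stronger effect. Compound 1 returns the highest of the three numbers, yet compound 3 lies only a few points lower and compound 2 a little further off, and both gaps fall within the scatter of repeated measurements, so no order among the three can be read from them. At the concentration tested, compound 1 shows no measurable effect, and the same holds for compound 2 and compound 3.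

Compound 4, `COc1cc(-c2cc(/C=C/C(=O)c3ccc(F)c(F)c3)[nH]n2)cc(OC)c1OC`, differs from compound 1 in one place: 3,4-difluorophenyl in place of 3,4-dichlorophenyl on a carbonyl carbon. Everything else in the molecule is unchanged. Going by the values given here, no step between two measured compounds exists to show what this swap does here. Since compound 1, compound 2 and compound 3 all return numbers near full activity, the step in this assay is expected to be none beyond the scatter, estimated as a number 2 percentage points lower from compound 1 to compound 4 (within the scatter). Compound 4 is therefore expected to give 100%, in a range from 88% to 110%.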

Compound 4, a percentage reported as activity, at one concentration (the size of the read-out at that concentration, not a potency): 106%
Beside the measured number, compound 4's estimate is 6 percentage points below it; measured number inside the range.
By their numbers in this assay, from the lowest: compounds 2, 3, 1 and 4 (each within the scatter of the next, the first and the last beyond it).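

Going by these compounds alone, the swap of 3,4-dichlorophenyl for 3,4-difluorophenyl on a carbonyl carbon supplies the first step that can be read in this assay: a number 4 percentage points higher from compound 1 to compound 4 (within the scatter). With the rest of the molecule unchanged, the two groups cannot be told apart at this place, and compound 4, like compound 1, shows no measurable effect at the concentration tested. Nothing measured here offers an explanation for this result.

From the compounds shown here alone, whether the two groups would also match at a concentration where compound 1 has a measurable effect remains open, as a single concentration without an effect cannot show this. Going by these compounds, it also remains open whether a phenyl ring carrying a nitrile or a carboxylic acid on that carbonyl carbon would give a number beyond the scatter from compound 1.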